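A Chlorine Added to the Benzyl Ether

A few compounds are considered here, and "the series" means these few. Any claim that something is new, unique, unknown or untested is made for them only; others in the source may bear on it.

Compound 3 `c1ccc(COc2ccccc2-c2nc3ccccc3[nH]2)cc1` stands with its value within the scatter of both other measured compounds in a functional assay on the whole organism (ileum) with Rattus norvegicus as the target (on this read-out lower numbers stand for smaller maximal responses and higher numbers for larger maximal responses), where compound 3 gives 51.4%. Compound 1 `COc1ccccc1-c1nc2ccccc2[nH]1` in this assay gives 52.8%, and compound 2 `CCOc1ccccc1-c1nc2ccccc2[nH]1` gives 50%. The three steps among them all stay within the scatter: a number 2.8 percentage points lower from compound 1 to compound 2 (within the scatter), a number 1.4 percentage points lower from compound 1 to compound 3 (within the scatter) and a number 1.4 percentage points higher from compound 2 to compound 3 (within the scatter). Compound 4 `Clc1ccc(COc2ccccc2-c2nc3ccccc3[nH]2)cc1` differs from compound 3 in one place: chloro in place of hydrogen on an aromatic carbon, on an aromatic carbon of a six-membered aromatic ring of carbon only, para to a large group; cut one bond further out, the change reads benzyl to 4-chlorobenzyl. Among the compounds with values here, no measured step involves a chloro group, so the only guide is that the three steps already seen, each within the scatter, alter the same end of the molecule without moving the maximal response. Compound 4 is therefore expected to give in this assay 51%, estimated within 40% to 62%, a step of a number 0.4 percentage points lower from compound 3 to compound 4 (within the scatter) that is expected to remain within the scatter.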

Compound 4, largest response reached (Emax), in percent of the reference or control that the assay uses: 38.2%
For compound 4 the middle estimate is 12.8 percentage points above the measured one; the measured number lies below the stated range.
By their numbers in this assay, from the lowest: compound 4; then compounds 2, 3 and 1 (each within the scatter of the next).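

In this assay, within the data shown here, chloro in place of hydrogen on an aromatic carbon, para to a large group, produces the first change that lies beyond the scatter: a number 13.2 percentage points lower from compound 3 to compound 4 (beyond the scatter). The earlier replacements at this end of the molecule had left the maximal response within the scatter, so the terminal phenyl ring tolerated no change here as readily as the benzyl group itself suggested; the 4-chlorobenzyl group also stands apart from the smaller ethers, with a number 11.8 percentage points lower from compound 2 to compound 4 (beyond the scatter) and a number 14.6 percentage points lower from compound 1 to compound 4 (beyond the scatter). Nothing available accounts for this fall in maximal response.

The compounds shown leave open whether the fall belongs to chlorine specifically or would also follow from fluoro, methyl or methoxy on the same aromatic carbon. They also do not show whether an amine or a carboxylic acid there would lower the response further or restore it.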